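Moving the Anilino Group on a Shared Core

The source may hold more compounds than are shown below. What is called first, only, known or untested is meant among the compounds shown, and "the series" means these compounds.

Two close analogues set the scene. Compound 1 `COc1ccc(Nc2nc(SCc3cn(Cc4ccccc4Cl)nn3)nc(-c3ccccc3)c2C#N)cc1` gives 39500 nM in an ADME assay on GES1 cells (Homo sapiens) for inhibition, read by MTT assay, with a stated time of 72 h (a lower number here means a stronger inhibitor, a higher number a weaker inhibitor), and compound 2 `N#Cc1c(Nc2ccc(Cl)cc2)nc(SCc2cn(Cc3ccccc3Cl)nn2)nc1-c1ccccc1` gives 39900 nM in this assay. The single step between them, a 1.0-fold higher number from compound 1 to compound 2 (0.00 log units; within the scatter), shows that exchanging one group for another on that aromatic carbon left the number unchanged within the scatter, so compound 2 and compound 1 stand together on the numbers shown.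

Compound 3 `COc1ccccc1Nc1nc(SCc2cn(Cc3ccccc3Cl)nn2)nc(-c2ccccc2)c1C#N` takes the same core one step further: 2-methoxyphenyl in place of 4-chlorophenyl on a nitrogen on an aromatic ring. For the measured compounds named here, the only measured step that bears on this change is the swap on the same ring from compound 1 to compound 2, which stayed within the scatter. On that basis no step beyond the scatter is expected for a 1.0-fold higher number from compound 2 to compound 3 (0.00 log units; within the scatter). Compound 3 is therefore estimated at 40000 nM in this assay, with a range from 15000 nM to 100000 nM.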

Compound 3, half-maximal inhibitory concentration: 37100 nM
Estimate against measurement, compound 3: 1.1-fold (0.03 log units) above, within the range that was stated.
By their numbers in this assay, from the lowest: compounds 3, 1 and 2 (each within the scatter of the next).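

In this assay, for the compounds shown here, moving from 4-methoxyphenyl to 2-methoxyphenyl on this nitrogen stays within the scatter (a 1.1-fold lower number from compound 1 to compound 3 (0.03 log units; within the scatter)), which the earlier compounds could not show, since they kept their group in one place on the ring and changed only its identity. Changing both the group and its place at once, with 2-methoxyphenyl in place of 4-chlorophenyl, also stays within the scatter (a 1.1-fold lower number from compound 2 to compound 3 (0.03 log units; within the scatter)), so the three aryl groups on this nitrogen stand together on these numbers. Nothing available here accounts for this flat result.

The compounds shown leave open whether a carboxylic acid or an amine on this phenyl ring would take the number beyond the scatter. They also leave open whether the same holds for a saturated ring such as cyclohexyl in place of the phenyl ring on this nitrogen.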